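The compounds below may be only part of what the source reports. "The series", "measured", "known", "first", "only" and "open" are said of these compounds alone.

Measured in a functional assay on L1210 cells (Mus musculus) for inhibition; on this read-out higher numbers stand for weaker inhibition and lower numbers for stronger inhibition:
- Compound 1 `C#CCN(Cc1ccc2nc(C)nc(O)c2c1)c1cccc(CC)c1`: 5000 nM
- Compound 2 `C#CCN(Cc1ccc2nc(C)nc(O)c2c1)c1ccc(C#N)cc1`: > 5000 nM (a limit, not a number)

Compound 2 therefore has no exact position on the scale, only (the limit of > 5000 nM in this assay, at which 1 of the 2 values shown sits). Compound 3 `C#CCN(Cc1ccc2nc(C)nc(O)c2c1)c1ccc(S(=O)(=O)C(F)(F)F)cc1` has (trifluoromethyl)sulfonyl in place of cyano on an aromatic carbon, para to a large group: (trifluoromethyl)sulfonyl in place of cyano on an aromatic carbon. Among the measured compounds shown here, only one measured step bears on this change, a number no lower from compound 1 to compound 2 (the limit leaves the size open), and its size cannot be read, so it offers no size to carry over. No clear change beyond the scatter is therefore expected, and the estimated step is a step that the limit leaves unreadable from compound 2 to compound 3. Compound 3 is expected at 6000 nM, with an estimated range of 2500 nM to 15000 nM.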

Compound 3, half-maximal inhibitory concentration: 2750 nM
The estimate for compound 3 lay 2.2-fold (0.34 log units) above the measured number; measured number inside the range.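

In this assay, (trifluoromethyl)sulfonyl gives this aromatic carbon, para to a large group, its first exact number, something cyano did not give: the change is an at least 1.8-fold lower number from compound 2 to compound 3 (0.25 log units; that floor lies within the scatter). Compound 2 carries a limit, not a number: the limit of > 5000 nM in this assay, at which 1 of the 3 values shown sits.

So the true size of this step stays unknown, and what can be read of it does not yet establish a real gain. Going by these compounds, whether an amine or a carboxylic acid on this same carbon would give a lower number remains open.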